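Three acylamino and imine variants of one sulfonamide core

The source may hold more compounds than are shown below. What is called first, only, known or untested is meant among the compounds shown, and "the series" means these compounds.

Measured so far:
compound 1 `Cc1ccc(C(=O)NC2=C(C#N)C(c3ccc(Cl)cc3Cl)C3=C(CCCC3=O)N2c2ccc(S(N)(=O)=O)cc2)cc1`, 40%
compound 2 `CN(C)c1ccc(/C=N/C2=C(C#N)C(c3ccc(Cl)cc3Cl)C3=C(CCCC3=O)N2c2ccc(S(N)(=O)=O)cc2)cc1`, 30%
compound 3 `CC(=O)CC(=O)NC1=C(C#N)C(c2ccc(Cl)cc2Cl)C2=C(CCCC2=O)N1c1ccc(S(N)(=O)=O)cc1`, 60%

In a functional assay on Ehrlich cells (Mus musculus) for cytotoxicity, read by trypan blue exclusion, with a stated time of 2 h, tested at 50 ug/mL (a higher number here means a stronger effect of the compound at the concentration tested, a lower number a weaker effect), compound 3 gives 60%, the highest of the three numbers; the step of a number 20 percentage points higher from compound 1 to compound 3 (beyond the scatter) and the step of a number 30 percentage points higher from compound 2 to compound 3 (beyond the scatter) both lie beyond the scatter, so compound 3 stands clearly above the other two.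

Compound 4 `CCO/C=N/C1=C(C#N)C(c2ccc(Cl)cc2Cl)C2=C(CCCC2=O)N1c1ccc(S(N)(=O)=O)cc1` carries a smaller group on the shared core: a group of 5 heavy atoms (3 carbon, 1 nitrogen, 1 oxygen; no ring) in place of a group of 7 heavy atoms (4 carbon, 1 nitrogen, 2 oxygen; no ring), on a double-bonded ring carbon. The entering group, like the group of compound 2, is joined through a double bond on nitrogen and lacks the hydrogen-bond donor of the ((2-oxopropyl)carbonyl)amino group. The step of a number 30 percentage points higher from compound 2 to compound 3 (beyond the scatter) is the closest guide, and it shows that moving from such a double-bonded nitrogen group to the acyl group raised the read-out by a modest amount. Reversing that direction, compound 4 is expected to fall back toward the value of compound 2, with an estimated step of a number 20 percentage points lower from compound 3 to compound 4 (beyond the scatter). Compound 4 is therefore estimated at 40%, with a likely range from 20% to 60%.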

Compound 4, a percentage reported as activity, at one concentration (the size of the read-out at that concentration, not a potency): 35%
Compound 4: middle estimate off by 5 percentage points, on the high side; measured number inside the range.
By their numbers in this assay, from the lowest: compounds 2, 4 and 1 (each within the scatter of the next); then compound 3.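

At this place on the shared core, in this assay, compound 3 now stands apart from a small group without a ring as well as from the two larger groups that carry a ring: the change to the ethoxy-bearing group gives a number 25 percentage points lower from compound 3 to compound 4 (beyond the scatter), so the lower numbers are not tied to an aromatic ring. Group size alone does not order these numbers either: ethoxy in place of 4-(dimethylamino)phenyl gives a number 5 percentage points higher from compound 2 to compound 4 (within the scatter), and the exchange for the larger ring-bearing amide group gives a number 5 percentage points lower from compound 1 to compound 4 (within the scatter). No measurement here bears on the cause of these differences.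

From the compounds shown here alone, the change to compound 4 removes the amide hydrogen and the 2-oxopropyl carbonyl together, so their separate contributions stay open. A plain acetylamino group, a longer 3-oxobutyl chain on the same carbonyl carbon, or a free amine at this place could help to separate them.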